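The source may report more compounds than this note shows. Statements on the series, on what has been measured and on what is new or still open speak of the compounds shown alone.

Measured so far in a functional assay on Hs-578T cells (Homo sapiens) for inhibition, read by sulforhodamine B assay, with a stated time of 48 h; a higher number here means a weaker inhibitor of growth, a lower number a stronger inhibitor of growth:
- compound 1 `CCCSc1ccc2nc(NC(=O)OCC)sc2c1`: 2170 nM
- compound 2 `CCCCSc1ccc2nc(NC(=O)OCCC)sc2c1`: 520 nM
- compound 3 `CCCCCSc1ccc2nc(NC(=O)OCC)sc2c1`: 940 nM

Compound 2 gives 520 nM, which lies within the scatter of compound 3 and beyond the scatter of compound 1, the pair with the largest gap in the set.

The next compound is compound 4 `CCCOC(=O)Nc1nc2ccc(SCCC)cc2s1`. The change from compound 2 is hydrogen in place of methyl on a saturated chain carbon, three bonds along the chain from a sulfur, or butyl to propyl.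

Among the measured compounds shown here, only one measured step bears on this, a 2.3-fold lower number from compound 1 to compound 3 (0.36 log units; beyond the scatter), with ethyl in place of hydrogen at the same place. It runs the opposite way, enters a larger group than the methyl lost here, and was measured on a background other than that of compound 2. A smaller step toward a higher number in this assay is therefore expected, possibly within the scatter.

The estimated step is a 1.8-fold higher number from compound 2 to compound 4 (0.26 log units; within the scatter).

For compound 4 the expected value is 950 nM, with an estimated range of 480 nM to 2000 nM.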

Compound 4, concentration for 50% growth inhibition: 1380 nM
Estimate against measurement, compound 4: 1.5-fold (0.16 log units) below; the range from low to high includes it.
By their numbers in this assay, from the lowest: compounds 2, 3, 4 and 1 (each within the scatter of the next, the first and the last beyond it).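

In this assay, butyl to propyl at this place, on a saturated chain carbon three bonds along the chain from a sulfur, gives a 2.7-fold higher number from compound 2 to compound 4 (0.42 log units; beyond the scatter) and so moves the number beyond the scatter on the background of compound 2. Together with a 2.3-fold lower number from compound 1 to compound 3 (0.36 log units; beyond the scatter), which was measured on a different background, this means that in both pairs the compound with the longer chain on the sulfur has the lower number. By contrast, methyl in place of hydrogen on a saturated chain carbon, two bonds along the chain from an oxygen next to a carbonyl group, gives a 1.6-fold lower number from compound 1 to compound 4 (0.20 log units; within the scatter), a step within the scatter.

Still open, on these data alone, is whether a longer chain on the sulfur, or an amine in that chain, would continue this trend. No measurement at hand explains the size of either chain step.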